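A shorter chain on a weak inhibitor

A few compounds are considered here, and "the series" means these few. Any claim that something is new, unique, unknown or untested is made for them only; others in the source may bear on it.

Measured so far in a toxicity assay on MRC5 cells (Homo sapiens) for inhibition, read by MTT assay, with a stated time of 72 h; a lower number here means a stronger inhibitor, a higher number a weaker inhibitor:
Compound 1 (`CCCCCCCCCCCCCCCC(=O)OCCc1ccc(O)c(O)c1`) gives > 50000 nM (a limit)
Compound 2 (`CCCCCCCCCC(=O)OCCc1ccc(O)cc1`) gives 172000 nM (a number)
Compound 3 (`CCCCCCCCCCC(=O)OCCc1ccc(OCc2ccccc2)c(OCc2ccccc2)c1`) gives > 50000 nM (a limit)

Compound 1 stands at a limit in this assay and has no exact number (> 50000 nM). Compound 4 (`CCCCCCCC(=O)OCCc1ccc(O)c(O)c1`) differs from it in one place (hydrogen in place of octyl on a saturated chain carbon, seven bonds along the chain from a carbonyl carbon): hydrogen in place of octyl on a saturated chain carbon, seven bonds along the chain from a carbonyl carbon. Going by the values given here, no measured pair isolates this change. Compound 2 gives a number (172000 nM) that marks weak inhibition, and this is the basis for expecting compound 4 to stay weak. Expected is a small step, or none beyond the scatter (a step that the limit leaves unreadable from compound 1 to compound 4). For compound 4 the estimated value is 70000 nM (expected range 30000 nM to 180000 nM).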

Compound 4, half-maximal inhibitory concentration: 104000 nM
Compound 4: the middle estimate sits 1.5-fold (0.17 log units) below what was measured, within the range that was stated.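

No step can be read from compound 1 to compound 4, because compound 1 has only a limit and no exact number: the limit of > 50000 nM in this assay, at which 2 of the 4 values shown sit.

The compounds shown leave open whether the shorter chain of compound 4 changes inhibition at all.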